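The source may hold more compounds than are shown below. What is called first, only, known or untested is meant among the compounds shown, and "the series" means these compounds.

Compound 1, `COc1cccc(/C=C/C(=O)c2sc(Nc3ccccc3)nc2C)c1`, gives > 25000 nM in a functional assay on Bel-7402 cells (Homo sapiens) for cytotoxicity, read by MTT assay (on this read-out higher numbers stand for weaker inhibition and lower numbers for stronger inhibition), which is a limit of the assay and not a number.
Compound 2, `Cc1nc(Nc2ccccc2)sc1C(=O)/C=C/c1ccccc1`, gives > 25000 nM in this assay, again a limit and not a number.

For the measured compounds named here, compound 1 therefore stands at the edge of what this assay reports, with no measured number of its own, and the only other value shown is also a limit. Going by the values given here, the single measured step, a step that the two limits leave unreadable from compound 1 to compound 2, cannot be sized, because of the limit of > 25000 nM in this assay, at which 2 of the 2 values shown sit. Compound 3, `COc1cccc(/C=C/C(=O)c2sc(Nc3ccccc3C)nc2C)c1`, differs from compound 1 by methyl in place of hydrogen on an aromatic carbon. No measured step touches this part of the shared core, so nothing shown indicates a direction for the change. With both measured compounds at the limit, the expectation for compound 3 is that it remains there as well, and the step that the limit leaves unreadable from compound 1 to compound 3 is estimated as one that stays within the scatter rather than a real shift. On that basis compound 3 is expected to give about 40000 nM in this assay, within a range of 10000 nM to 200000 nM, most likely reported only as a limit.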

Compound 3, half-maximal inhibitory concentration: > 25000 nM
Compound 3: only a limit was reported; the forecaster's own chance of this, stated with the estimate: 80%; the middle value lies beyond the limit too.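

No size can be read for the change from compound 1 to compound 3, since compound 3 also gives a limit and not a number: the limit of > 25000 nM in this assay, at which 3 of the 3 values shown sit.

The compounds shown leave open how strongly compound 1, compound 2 and compound 3 act in this assay, and whether either single change on the shared core alters the read-out.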